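A few compounds are considered here, and "the series" means these few. Any claim that something is new, unique, unknown or untested is made for them only; others in the source may bear on it.

Measured in an ADME assay on L02 cells (Homo sapiens) for cytotoxicity, read by MTT assay, with a stated time of 24 h; a lower number here means a stronger inhibitor, a higher number a weaker inhibitor:

- compound 1 `CN1C/C(=C\c2ccc(C(F)(F)F)cc2)C(=O)/C(=C/c2ccccc2F)C1`: 18600 nM
- compound 2 `CN1C/C(=C\c2ccc(C(F)(F)F)cc2)C(=O)/C(=C/c2cccc([N+](=O)[O-])c2)C1`: 12400 nM
- compound 3 `CN1C/C(=C\c2ccc(Cl)cc2)C(=O)/C(=C/c2ccc(C#N)cc2)C1`: 16200 nM

These three values lie close together. Compound 3, at 16200 nM, falls within the usual scatter of repeated measurements of both compound 1 and compound 2, so it cannot be ranked against either.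

The next compound is compound 4 `CN1C/C(=C\c2ccc(C#N)cc2)C(=O)/C(=C/c2ccc(C(F)(F)F)cc2)C1`. Its difference from compound 3 is trifluoromethyl in place of chloro on an aromatic carbon, which is trifluoromethyl in place of chloro on an aromatic carbon.

Among the measured compounds shown here, no measured step makes this exchange. For the measured compounds named here, the only measured step, a 1.5-fold lower number from compound 1 to compound 2 (0.18 log units; within the scatter), puts 3-nitrophenyl in place of 2-fluorophenyl, a different change in a different place, and it stays within the scatter. It therefore offers only indirect guidance. Compound 1 and compound 2 carry trifluoromethyl while compound 3 carries chloro, and their values do not separate beyond the scatter, although these compounds also differ elsewhere.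

With so little evidence, no shift beyond the scatter is expected in this assay. The estimated change is a 1.1-fold lower number from compound 3 to compound 4 (0.03 log units; within the scatter), which is expected to be too small to distinguish from repeat variation. The estimate for compound 4 is 15000 nM, with an expected range of 8000 nM to 28000 nM.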

Compound 4, half-maximal inhibitory concentration: 17200 nM
Compound 4: middle estimate off by 1.1-fold (0.06 log units), on the low side, and the stated range covers the measured number.
By their numbers in this assay, from the lowest: compounds 2, 3, 4 and 1 (each within the scatter of the next).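

In this assay, the exchange of chloro for trifluoromethyl on an aromatic carbon can now be read directly: it gives a 1.1-fold higher number from compound 3 to compound 4 (0.03 log units; within the scatter), so these two groups cannot be told apart at this position in this cytotoxicity measure. The other aromatic group on the double-bonded chain carbon bound to a double-bonded ring carbon behaves alike, since 4-cyanophenyl in place of 3-nitrophenyl gives a 1.4-fold higher number from compound 2 to compound 4 (0.14 log units; within the scatter) and 4-cyanophenyl in place of 2-fluorophenyl gives a 1.1-fold lower number from compound 1 to compound 4 (0.03 log units; within the scatter), which means all three of these groups fall within repeat variation of one another. No measurement at hand speaks to what lies behind this lack of separation.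

Every group compared so far is a substituted phenyl carrying no net charge, so the compounds shown cannot tell whether any exchange at these places would move the number beyond the scatter. An amine or a carboxylic acid on the aromatic ring, or a longer chain in place of trifluoromethyl, would be the kind of group needed to test that question.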